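Bromo in Place of Fluoro: An Expected Lipophilicity for Compound 4

A few compounds are considered here, and "the series" means these few. Any claim that something is new, unique, unknown or untested is made for them only; others in the source may bear on it.

Of the compounds shown here, three of one series have been measured in a physicochemical assay for lipophilicity; a lower number here means a more polar compound, a higher number a more lipophilic compound. Compound 1 `Nc1nc(N)nc(-c2cc(Cl)ccc2Br)n1` gives 1.85. Compound 2 `Nc1nc(N)nc(-c2cc(Cl)ccc2F)n1` gives 1.81 in this assay. Compound 3 `Nc1nc(N)nc(-c2cc(F)ccc2Br)n1` gives 1.45 in this assay, the lowest of the three. From compound 2 to compound 1 the change is bromo in place of fluoro on an aromatic carbon and it made a number 0.04 log units higher from compound 2 to compound 1 (within the scatter). From compound 1 to compound 3 the step was a number 0.40 log units lower from compound 1 to compound 3 (beyond the scatter). The difference between the cores of compound 2 and compound 3 is not broken down here.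

Compound 4 `Nc1nc(N)nc(-c2cc(Br)ccc2Br)n1` has not yet been measured. From compound 3 to compound 4 the change is bromo in place of fluoro on an aromatic carbon, the same kind of change as that from compound 2 to compound 1, though not the same: there the entering bromo sat ortho to a group of 8 heavy atoms and para to a chloro group, here it sits meta to a group of 8 heavy atoms and para to a bromo group. The step expected here is a number 0.25 log units higher from compound 3 to compound 4 (within the scatter), resting on the earlier change of this kind, which made a number 0.04 log units higher from compound 2 to compound 1 (within the scatter), with some allowance for the different place. Compound 4 is therefore expected at 1.7 in this assay, with a likely range from 1.4 to 2.1.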

Compound 4, partition coefficient: 2.09
For compound 4 the middle estimate is 0.39 log units below the measured one; measured number inside the range.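

Carried from one core to the other, bromo in place of fluoro kept its direction in this assay but not its size: it gave a number 0.04 log units higher from compound 2 to compound 1 (within the scatter), whereas the new step gave a number 0.64 log units higher from compound 3 to compound 4 (beyond the scatter), so the one pair within the scatter and the other beyond it show that the earlier step could not be transferred as a fixed increment. Within the data shown here, the further step, a number 0.24 log units higher from compound 1 to compound 4 (within the scatter), also lies within the scatter, so these two compounds cannot be placed in order, and this series offers only one pair for each of the two places, which does not separate the effect of the place from that of the group para to it. Nothing shown here explains why the two steps differ.

As far as these compounds go, it remains open how a nitrile or a methoxy group entering at the same place would read in this assay, and whether an amine there would follow the halogens. A further pair carrying the same change would be needed to tell whether the larger step or the smaller one is typical of this series.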